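Compound 4: a 2-Methylphenyl Group Replacing Bromo

The source may report more compounds than this note shows. Statements on the series, on what has been measured and on what is new or still open speak of the compounds shown alone.

Three compounds have been measured in an assay on cells for agonist activity at probable G-protein coupled receptor 34 (Mus musculus), with a stated time of 1 h; on this read-out lower numbers stand for smaller maximal responses and higher numbers for larger maximal responses:

compound 1 `N[C@@H](COP(=O)(O)OCCCOC(=O)CCc1ccccc1OCc1cccc(Cc2ccccc2)c1)C(=O)O`: 14.5%
compound 2 `Cc1ccc(Oc2cccc(COc3ccccc3CCC(=O)OCCCOP(=O)(O)OC[C@H](N)C(=O)O)c2)cc1`: 18.2%
compound 3 `N[C@@H](COP(=O)(O)OCCCOC(=O)CCc1ccccc1OCc1cccc(Oc2ccc(Br)cc2)c1)C(=O)O`: 17.7%

Compound 3 stands second highest of the three numbers. Its nearest neighbour is compound 2, a number 0.5 percentage points lower from compound 2 to compound 3 (within the scatter). The furthest is compound 1, a number 3.2 percentage points higher from compound 1 to compound 3 (within the scatter). The remaining pair shows a number 3.7 percentage points higher from compound 1 to compound 2 (within the scatter). All three steps lie within the scatter, so the three compounds cannot be ranked on these numbers.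

Compound 4 `Cc1ccccc1-c1ccc(Oc2cccc(COc3ccccc3CCC(=O)OCCCOP(=O)(O)OC[C@H](N)C(=O)O)c2)cc1` differs from compound 3 in one place: 2-methylphenyl in place of bromo on an aromatic carbon.

The step that bears most directly on this change is the one at the same place, a number 0.5 percentage points lower from compound 2 to compound 3 (within the scatter), which was within the scatter. The two steps from compound 1, a number 3.7 percentage points higher from compound 1 to compound 2 (within the scatter) and a number 3.2 percentage points higher from compound 1 to compound 3 (within the scatter), were also within the scatter. Going by the values given here, no measured step introduces a group as large as 2-methylphenyl, so the data give no basis for expecting a step beyond the scatter in this assay, and the expected step is a number 0.3 percentage points higher from compound 3 to compound 4 (within the scatter). Compound 4 is therefore estimated to give 18%, within a range of 8% to 30%.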

Compound 4, largest response reached (Emax), in percent of the reference or control that the assay uses: 13.4%
The estimate for compound 4 lay 4.6 percentage points above the measured number, and the stated range covers the measured number.
By their numbers in this assay, from the lowest: compounds 4, 1, 3 and 2 (each within the scatter of the next).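

At the aromatic carbon para to a large group, 2-methylphenyl brings 7 heavy atoms and one six-membered aromatic ring of carbon only, and in this assay its exchange for bromo gives a number 4.3 percentage points lower from compound 3 to compound 4 (within the scatter) while its exchange for methyl gives a number 4.8 percentage points lower from compound 2 to compound 4 (within the scatter). The earlier compounds shown here carried only bromo or methyl at this place, so they could not show that a whole added aromatic ring there still leaves both steps within the scatter. Nothing available on these compounds accounts for this result.

The compounds shown do not tell whether a plain phenyl ring, without its methyl group, or a ring bearing an amine or a carboxylic acid at this same carbon would give a step beyond the scatter. Since all four compounds lie within the scatter of the next in this ranking, they also leave open whether any change at this position moves the maximal response at all, or whether a longer chain elsewhere on the shared core would do so instead.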